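This account rests on a few compounds, and the source may have more. Where it says the series, first, only, none or still open, it means among the compounds named here.

Working notes on the series, values from an ADME assay for protein binding, using equilibrium dialysis, at pH 7.4, tested at 2 uM; a lower number here means a smaller unbound share, a higher number a larger unbound share of the compound:

- compound 1 `CC(C)(C)C#Cc1cc(N(C(=O)[C@H]2CC[C@H](C)CC2)[C@H]2C[C@@H](Oc3cccnc3)C2)c(C(=O)O)s1`: 0.04
- compound 2 `CC(C)N(C(=O)C1CCC(F)(F)CC1)c1cc(C#CC(C)(C)C)sc1C(=O)O`: 0.4
- compound 3 `CC(C)N(C(=O)[C@H]1CC[C@@H]2C[C@@H]2CC1)c1cc(C#CC(C)(C)C)sc1C(=O)O`: 0.08

Compound 1 at 0.04 and compound 3 at 0.08 lie within the scatter of each other, while compound 2 at 0.4 stands beyond the scatter on the higher side of both.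

Next is compound 4 `C[C@@H](CCOc1cccnc1)N(c1cc(C#CC(C)(C)C)sc1C(=O)O)C(=O)[C@H]1CC[C@H](C)CC1`, which carries 1-methyl-3-((pyridin-3-yl)oxy)propyl in place of 3-((pyridin-3-yl)oxy)cyclobutyl on an amide-type nitrogen.

Going by the values given here, the one measured step, a 5.0-fold lower number from compound 2 to compound 3 (0.70 log units; beyond the scatter), is a modest one, but it lies on a carbonyl carbon and so bears on this change only indirectly. Among the compounds with values here, no step at the amide-type nitrogen has been measured. With no evidence for a shift, no change beyond the scatter is expected in this assay, and the starting point remains compound 1 at 0.04. The expected step is a 1.3-fold higher number from compound 1 to compound 4 (0.10 log units; within the scatter). Compound 4 is estimated at 0.05, with an expected range from 0.02 to 0.12.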

Compound 4, unbound fraction: 0.02
Compound 4: the middle estimate sits 2.5-fold (0.40 log units) above what was measured, and the stated range covers the measured number.
By their numbers in this assay, from the lowest: compounds 4, 1 and 3 (each within the scatter of the next, the first and the last beyond it); then compound 2.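

Going by these compounds alone, this is the first step read at the amide-type nitrogen: in this assay, 1-methyl-3-((pyridin-3-yl)oxy)propyl in place of 3-((pyridin-3-yl)oxy)cyclobutyl gives a 2.0-fold lower number from compound 1 to compound 4 (0.30 log units; within the scatter), so here the four-membered ring can give way to an open chain without a step beyond the scatter. The exchange keeps the heavy-atom count and the pyridine ring, while the defined stereocentres in the group go from 2 to 1. Nothing at hand accounts for the size of this step.

Still open, as far as these compounds go, is how a longer chain on the amide-type nitrogen, or a primary amine or a carboxylic acid in place of the pyridine ring, would read in this assay. Also open, from the compounds shown here alone, is whether a 5.0-fold lower number from compound 2 to compound 3 (0.70 log units; beyond the scatter), read on a carbonyl carbon, would carry over to compounds with the chain of compound 4.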